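Shifting the methoxy group from compound 1 to compound 4

A few compounds are considered here, and "the series" means these few. Any claim that something is new, unique, unknown or untested is made for them only; others in the source may bear on it.

Of the compounds shown here, three have been tested in a physicochemical assay for pharmacokinetics; a higher number here means that the compound lasts longer, a lower number that the compound disappears faster. Compound 1 `COc1cccc(CNC(=O)N2C(=O)c3ccccc3S2(=O)=O)c1` sits at a limit of the assay: in this assay compound 1 gives > 166 h, which is a limit and not a number. Compound 3 `O=C(c1ccccc1)N1Cc2ccccc2C1=O` also sits at a limit, as in this assay compound 3 gives > 166 h. Compound 2 `O=C(CCc1ccccc1)N1C(=O)c2ccccc2S1(=O)=O` reaches a different limit, since in this assay compound 2 gives > 5.77 h. Among the measured compounds shown here, two of the three values therefore stop at the limit of > 166 h in this assay, at which 2 of the 3 values shown sit, and one at the limit of > 5.77 h in this assay, at which 1 of the 3 values shown sits; none is a plain number, so no step between measured compounds can be sized, and compound 1 is known only to last past its limit.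

Compound 4 `COc1ccccc1CNC(=O)N1C(=O)c2ccccc2S1(=O)=O` differs from compound 1 in one place: 2-methoxyphenyl in place of 3-methoxyphenyl on a saturated chain carbon bound to an amide-type nitrogen. Nothing measured shows how such a change acts in this assay. Given that compound 1 already lies at the limit of > 166 h in this assay, at which 2 of the 3 values shown sit, the step from compound 1 to compound 4 is expected to be no change beyond the scatter, a number no higher from compound 1 to compound 4 (the limit leaves the size open). Compound 4 is therefore estimated at 166 h, between 50 h and 500 h, most likely again reported only as a limit.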

Compound 4, half-life: > 166 h
Compound 4 gave a limit, no number; the forecaster's own chance of this, stated with the estimate: 75%; the middle value sits exactly at the limit.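

In this assay compound 1 and compound 4 both stop at the same limit, so the step between them cannot be read: the limit of > 166 h in this assay, at which 3 of the 4 values shown sit.

The compounds shown leave open how long any of them actually lasts, and whether 2-methoxyphenyl and 3-methoxyphenyl differ at all here.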